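The compounds below may be only part of what the source reports. "The series", "measured", "known", "first", "only" and "open" are said of these compounds alone.

Two compounds of this series have been run in a functional assay on the whole organism (strain CD-1) with Mus musculus as the target, with a stated time of 2 h; on this read-out higher numbers stand for an effect only at larger amounts of compound and lower numbers for an effect already at smaller amounts. Compound 1 `CC1(c2ccccc2)CC(=O)N(CC(=O)N2CCC(Cc3ccccc3)CC2)C1=O` gives "not active" (no number reported), without a number. Compound 2 `CC1(c2ccccc2)CC(=O)N(CC(=O)N2CCN(c3ccccc3Cl)CC2)C1=O` gives 100 mg/kg, the only figure available in this assay, so compound 2 stands alone on it. Compound 3 `CC1(c2ccccc2)CC(=O)N(CC(=O)N2CCN(c3cccc(C(F)(F)F)c3)CC2)C1=O` is not yet measured. It differs from compound 2 in one place: 3-(trifluoromethyl)phenyl in place of 2-chlorophenyl on an amine nitrogen in a ring. Within the data shown here, with a single number and no measured step to lean on, the step of no change at the digits printed from compound 2 to compound 3 (within the scatter) is expected to stay within the usual scatter, in no set direction. Compound 3 is therefore estimated at 100 mg/kg, with a range from 30 mg/kg to 300 mg/kg.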

Compound 3, minimum effective dose: "not active" (no number reported)
For compound 3 the study gives words and no number; no gap can be computed for the estimate.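

In this assay, among these compounds, compound 3 has words and no number, so no step from compound 2 to compound 3 can be read. The compounds shown leave open which aryl groups on the ring nitrogen give a numbered dose. No measured evidence bears on this result.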